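Removing the Methoxy Group from a Benzylamine Sulfonamide

The compounds below may be only part of what the source reports. "The series", "measured", "known", "first", "only" and "open" are said of these compounds alone.

Measured so far in a functional assay on HPAC cells (Homo sapiens) for inhibition, read by MTT assay, with a stated time of 72 h; a lower number here means a stronger inhibitor of growth, a higher number a weaker inhibitor of growth:
compound 1 `O=S(=O)(NCCCNCc1cccc(Cl)c1)c1cc(C(F)(F)F)cc(C(F)(F)F)c1`: 2700 nM
compound 2 `O=S(=O)(NCCCNCc1ccc(C(F)(F)F)cc1)c1cc(C(F)(F)F)cc(C(F)(F)F)c1`: 2700 nM
compound 3 `COc1ccccc1CNCCCNS(=O)(=O)c1cc(C(F)(F)F)cc(C(F)(F)F)c1`: 2400 nM

Compound 3 holds the lowest of the three numbers, but only narrowly: a 1.1-fold lower number from compound 1 to compound 3 (0.05 log units; within the scatter) and a 1.1-fold lower number from compound 2 to compound 3 (0.05 log units; within the scatter) both lie within the scatter, as does no change at the digits printed from compound 1 to compound 2 (within the scatter). Across these three compounds the group carried on the benzylic ring has made no difference that can be told apart from repeat measurements.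

Compound 4 `O=S(=O)(NCCCNCc1ccccc1)c1cc(C(F)(F)F)cc(C(F)(F)F)c1` differs from compound 3 in one place: hydrogen in place of methoxy on an aromatic carbon. Among the compounds with values here, none of the measured steps removes a group outright; each swaps one substituent for another, and every one of them stayed within the scatter. There is therefore no basis in the data for expecting a step beyond the scatter here either. Compound 4 is expected to land close to compound 3, with a 1.3-fold higher number from compound 3 to compound 4 (0.10 log units; within the scatter) as the anticipated shift. The estimate for compound 4 in this assay is 3000 nM, with a range from 1500 nM to 6000 nM.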

Compound 4, concentration for 50% growth inhibition: 3200 nM
Compound 4: the middle estimate sits 1.1-fold (0.03 log units) below what was measured; measured number inside the range.
By their numbers in this assay, from the lowest: compounds 3, 1, 2 and 4 (each within the scatter of the next).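

Taking a substituent off the ring outright, a change no earlier step made, still gives a step within the scatter in this assay (a 1.3-fold higher number from compound 3 to compound 4 (0.12 log units; within the scatter)) where methoxy leaves. The same holds where trifluoromethyl leaves (a 1.2-fold higher number from compound 2 to compound 4 (0.07 log units; within the scatter)) and where chloro leaves (a 1.2-fold higher number from compound 1 to compound 4 (0.07 log units; within the scatter)), so among these four compounds the unsubstituted phenyl ring can be told apart from none of the substituted ones. Nothing at hand bears on what lies behind this flat result.

The compounds shown leave open whether a group of another kind on this ring, such as a carboxylic acid or an amine, would give a step beyond the scatter. They also leave open what a longer chain in the part shared by all four compounds would do, since that part stays the same throughout.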